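Swapping cyano for trifluoromethyl in compound 1

The source may report more compounds than this note shows. Statements on the series, on what has been measured and on what is new or still open speak of the compounds shown alone.

Compound 1 `N#Cc1ccc(NC(=O)c2ccc(Cl)cc2O)cc1` gives 1300 nM
Compound 2 `N#Cc1ccc(NC(=O)c2ccc(-c3cccnc3)cc2O)cc1` gives 6660 nM

For the measured compounds named here, in a functional assay on HL-60 cells (Homo sapiens) for cytotoxicity, read by luminescence and CellTiter-Glo, with a stated time of 3 days (a lower number here means a stronger inhibitor, a higher number a weaker inhibitor), compound 1 holds the lower of the two numbers so far. Compound 3 `O=C(Nc1ccc(C(F)(F)F)cc1)c1ccc(Cl)cc1O` carries trifluoromethyl in place of cyano on an aromatic carbon. Going by the values given here, the only measured step (a 5.1-fold higher number from compound 1 to compound 2 (0.71 log units; beyond the scatter)) swaps pyridin-3-yl for chloro at another place, and no measured compound shows a change at the cyano place. That step therefore gives only a loose guide, and a small shift to a lower number, within the scatter, is expected. The expected step is a 1.6-fold lower number from compound 1 to compound 3 (0.21 log units; within the scatter) and remains an estimate. For compound 3 the estimated value is 800 nM (range 250 nM to 2500 nM).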

Compound 3, half-maximal inhibitory concentration: 630 nM
Estimate against measurement, compound 3: 1.3-fold (0.10 log units) above; low and high end bracket the measured number.
By their numbers in this assay, from the lowest: compound 3; then compound 1; then compound 2.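

In this assay, the change at this place, on an aromatic carbon para to a large group, gives a 2.1-fold lower number from compound 1 to compound 3 (0.31 log units; beyond the scatter) and so lowers the number beyond the scatter. The cyano group, with its triple bond and its hydrogen-bond acceptor, can therefore leave this place without the number rising, at least with chloro held constant. Nothing shown accounts for the direction of this step. Going by these compounds, whether an amine, a carboxylic acid or a methoxy group here would lower the number further remains open. So does whether trifluoromethyl gives the same step when pyridin-3-yl stands in place of chloro.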